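Oxime ether extension on the naphthyl diaryl core

This account rests on a few compounds, and the source may have more. Where it says the series, first, only, none or still open, it means among the compounds named here.

Compound 1 `COc1ccc(/C(=N/O)c2cccc3ccccc23)c(OC)c1OC` is the free oxime of the series and was tested in a functional assay on MCF7 cells (Homo sapiens) for inhibition, read by sulforhodamine B assay, with a stated time of 48 h; a higher number here means a weaker inhibitor, a lower number a stronger inhibitor. In this assay compound 1 gives only a limit, > 20000 nM, and not a number. Two further members share the core of compound 1. Compound 2 `C=CCC(O)(c1ccc(OC)c(OC)c1OC)c1cccc2ccccc12` carries a tertiary alcohol bearing an allyl chain; in this assay compound 2 likewise returns only a limit, > 20000 nM. Compound 3 `COc1ccc(C(c2ccc(OCCO)cc2)c2cccc3ccccc23)c(OC)c1OC` is a triarylmethane with a hydroxyethoxy side chain; in this assay compound 3 also stops at a limit, > 20000 nM. Where compound 1 stands is therefore a boundary rather than a position: all three values sit at the limit of > 20000 nM in this assay, at which 3 of the 3 values shown sit, and no order among compounds 1, 2 and 3 can be read from them.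

Compound 4 `CCOC(=O)/C=C/CO/N=C(/c1ccc(OC)c(OC)c1OC)c1cccc2ccccc12` is the unmeasured oxime ether; it differs from compound 1 by 3-(ethoxycarbonyl)prop-2-en-1-yl in place of hydrogen on an oxygen. Among the compounds with values here, no measured step in the set bears on this change, and the shared limit gives no direction. The step from compound 1 to compound 4 in this assay is therefore expected to be a step that the limit leaves unreadable from compound 1 to compound 4, nothing beyond the scatter. Compound 4 is expected to give 25000 nM in this assay, within 8000 nM to 80000 nM, most likely reported again only as a limit.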

Compound 4, half-maximal inhibitory concentration: > 20000 nM
Compound 4: only a limit was reported (the forecaster's own chance of this, stated with the estimate: 80%); the middle value is on the limit's open side.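

In this assay compound 4 gives only a limit, > 20000 nM. With compound 1 also at a limit, no step from compound 1 to compound 4 can be read: the limit of > 20000 nM in this assay, at which 4 of the 4 values shown sit.

Any order among the four compounds stays open, as does what 3-(ethoxycarbonyl)prop-2-en-1-yl in place of hydrogen on an oxygen does to inhibition.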